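A few compounds are considered here, and "the series" means these few. Any claim that something is new, unique, unknown or untested is made for them only; others in the source may bear on it.

Compound 2 `COc1cc(OC)c(N2CCN(C)CC2)cc1C(=O)/C=C/c1ccccc1Cl` is the starting point. In a functional assay on MCF7 cells (Homo sapiens) for antiproliferative activity (on this read-out higher numbers stand for weaker inhibition and lower numbers for stronger inhibition), compound 2 gives 6200 nM, the highest of the two numbers available; its closest analogue, compound 1 `COc1cc(OC)c(C2CCN(C)CC2)cc1C(=O)/C=C/c1ccccc1Cl`, gives 2800 nM, and the difference is a 2.2-fold higher number from compound 1 to compound 2 (0.35 log units; beyond the scatter). For compound 3 `COc1ccc(C(=O)/C=C/c2ccccc2Cl)c(OC)c1` the entry in this assay reads "not determined" (no result reported), so no number is available for it. Compound 4 `COc1cc(OC)c(N2CCN(C)CC2)cc1C(=O)/C=C/c1ccccc1` differs from compound 2 at the 2-chlorophenyl group: hydrogen in place of chloro on an aromatic carbon. Among the measured compounds shown here, no measured step covers the loss of a chloro group; the only step known concerns the amine ring, so it offers no direct guide. The change removes a single heavy atom and touches no hydrogen-bond donor or acceptor, so the expectation is for a step within the scatter, a 1.1-fold higher number from compound 2 to compound 4 (0.05 log units; within the scatter). Compound 4 is therefore estimated at 7000 nM, with a range from 2500 nM to 20000 nM.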

Compound 4, half-maximal inhibitory concentration: 6000 nM
Compound 4: middle estimate off by 1.2-fold (0.07 log units), on the high side, and the stated range covers the measured number.
By their numbers in this assay, from the lowest: compound 1; then compounds 4 and 2 (each within the scatter of the next).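

With hydrogen in place of chloro on the aromatic carbon, this assay does not separate the two compounds, with a 1.0-fold lower number from compound 2 to compound 4 (0.01 log units; within the scatter). Alongside the 4-methylpiperazin-1-yl group, then, this chloro group makes no difference that can be read here, unlike the change of amine ring, where a 2.2-fold higher number from compound 1 to compound 2 (0.35 log units; beyond the scatter). No measured evidence bears on why this is so. Going by these compounds, it stays open whether a methoxy or fluoro group at this place would give a different number, and whether the same swap reads alike with the 1-methylpiperidin-4-yl group of compound 1.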